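Methoxy added to the chlorophenyl side of compound 1

A few compounds are considered here, and "the series" means these few. Any claim that something is new, unique, unknown or untested is made for them only; others in the source may bear on it.

Compound 1 `CC(C)C[C@H](N)c1cc(Cl)ccc1N1CCN(C(=O)C(C)Cc2ccc(Cl)cc2)CC1` gives 67 nM in an assay on HEK293 cells for displacement of a labelled ligand from Melanocortin receptor 4 (Homo sapiens) (on this read-out higher numbers stand for weaker inhibition and lower numbers for stronger inhibition), the highest of the two numbers in hand; compound 2 `CC(C)C[C@H](N)c1cc(C(F)(F)F)ccc1N1CCN(C(=O)C(C)Cc2ccc(Cl)cc2)CC1` gives 47 nM, and the step of a 1.4-fold lower number from compound 1 to compound 2 (0.15 log units; within the scatter) concerns trifluoromethyl in place of chloro on an aromatic carbon. Compound 3 `COc1cc(Cl)ccc1CC(C)C(=O)N1CCN(c2ccc(Cl)cc2[C@@H](N)CC(C)C)CC1` differs from compound 1 by methoxy in place of hydrogen on an aromatic carbon, on an aromatic carbon ortho to a large group and meta to a chloro group. Going by the values given here, no measured step touches this position, so the change from compound 1 to compound 2 bears only indirectly on it. For compound 3 the expected step is no change at the digits printed from compound 1 to compound 3 (within the scatter), none beyond the scatter. Compound 3 is estimated at 67 nM, range 25 nM to 180 nM.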

Compound 3, inhibition constant: 9.1 nM
Compound 3: the middle estimate sits 7.4-fold (0.87 log units) above what was measured, and the stated range ends above it.
By their numbers in this assay, from the lowest: compound 3; then compounds 2 and 1 (each within the scatter of the next).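

Substitution on the 4-chlorobenzyl side of compound 1 can move the number: methoxy in place of hydrogen, ortho to a large group and meta to a chloro group, gives a 7.4-fold lower number from compound 1 to compound 3 (0.87 log units; beyond the scatter) in this assay. Going by these compounds alone, the one earlier step concerned a different position and stayed within the scatter, so this is the first change to go beyond it. No supporting measurement accounts for this step.

As far as these compounds go, whether hydroxy, ethoxy or fluoro at this position would give a similar number remains open. So does whether methoxy carries the same step onto compound 2, with its trifluoromethyl group.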